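The source may hold more compounds than are shown below. What is called first, only, known or untested is meant among the compounds shown, and "the series" means these compounds.

The measured compounds are three. Compound 1 `CCC(C)C(NC(=O)n1nnc2ccccc21)C(=O)NC(c1ccccc1)c1ccccc1` in a functional assay on WI-38 cells (Homo sapiens) for inhibition (a lower number here means a stronger inhibitor, a higher number a weaker inhibitor), gives 62700 nM. Compound 2 `CCC(C)C(NC(=O)n1nnc2ccccc21)C(=O)NC1CCCCC1` in this assay gives > 100000 nM, which is a limit of the assay and not a number. Compound 3 `CCC(C)C(NC(=O)NO)C(=O)NCc1ccccc1` in this assay gives > 100000 nM, again a limit of the assay rather than a number.

Compound 3 therefore stands at the edge of what this assay can report, and it is not alone there: of the three results, two sit at the limit of > 100000 nM in this assay, at which 2 of the 3 values shown sit, and only compound 1 returns an actual number. Among the measured compounds shown here, no step between measured compounds differing in one place is available, so nothing measured tells how much a single change moves the read-out.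

Compound 4 `CCC(C)C(NC(=O)n1nnc2ccccc21)C(=O)NCc1ccccc1` has not yet been measured in this assay. It differs from compound 3 in one place: a group of 9 heavy atoms (6 carbon, 3 nitrogen; one five-membered aromatic ring with 3 hetero atoms, one six-membered aromatic ring of carbon only) in place of a group of 2 heavy atoms (1 nitrogen, 1 oxygen; no ring), on a carbonyl carbon. In words, a group of 9 heavy atoms (6 carbon, 3 nitrogen; one five-membered aromatic ring with 3 hetero atoms, one six-membered aromatic ring of carbon only) takes the place of a group of 2 heavy atoms (1 nitrogen, 1 oxygen; no ring), on a carbonyl carbon. Compound 4 thus carries on that carbonyl carbon the same group as compound 1 and compound 2, of which compound 1 gave a number and compound 2 only a limit.

The expected step is estimated at a number no higher from compound 3 to compound 4 (the limit leaves the size open), that is, none beyond the scatter. Compound 4 is estimated at 100000 nM, within a range from 30000 nM to 300000 nM, with a real chance that this assay reports only a limit.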

Compound 4, half-maximal inhibitory concentration: > 100000 nM
Compound 4: a limit, no number; the forecaster's own chance of this, stated with the estimate: 60%; the middle value lies on the limit itself.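

With benzyl on the amide-type nitrogen, the group that compound 4 shares with compound 1 and compound 2 on the carbonyl carbon still gives no number, so that group alone does not bring a compound off the limit: the limit of > 100000 nM in this assay, at which 3 of the 4 values shown sit. The steps to compound 4 from compound 3 and from compound 2 cannot be read, as both ends of each are limits. Among the compounds shown here, the one step that can be read is an at least 1.5-fold higher number from compound 1 to compound 4 (0.20 log units; that floor lies within the scatter), for hydrogen in place of phenyl on a saturated chain carbon bound to an amide-type nitrogen and an aromatic carbon, and since its floor lies within the scatter, it does not yet show that this phenyl counts in this assay.

On these data alone, how far compound 2, compound 3 and compound 4 lie past the limit stays open, and with it whether hydroxyamino or the group that replaced it gives the stronger inhibition. Also open, as far as these compounds go, is how a longer chain, an amine or a carboxylic acid in place of that phenyl would read, and whether any such group would return a number at all.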